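The source may report more compounds than this note shows. Statements on the series, on what has been measured and on what is new or still open speak of the compounds shown alone.

Working notes on the series around compound 1 `CC1CCN(c2nc(Cl)nc3c2ncn3Cc2ccc(/C=C/C(=O)Nc3ccccc3N)cc2)CC1`. In a functional assay on NCI-H460 cells (Homo sapiens) for antiproliferative activity, read by CCK-8 assay, with a stated time of 72 h, tested at 8 uM (on this read-out higher numbers stand for a stronger effect at the one concentration tested and lower numbers for a weaker effect), compound 1 gives 10.8%, the lowest of the three numbers in hand. Compound 2 `CCCCn1cnc2c(NCc3ccc(C(=O)Nc4ccccc4N)cc3)nc(Cl)nc21` gives 23.7% in this assay, and compound 3 `Nc1ccccc1NC(=O)c1ccc(CNc2nc(Cl)nc3c2ncn3C2CCCC2)cc1` gives 57.4%; the gaps from compound 1 to each of the other two lie beyond the scatter. Among the compounds with values here, the only single-point step measured so far is a number 33.7 percentage points higher from compound 2 to compound 3 (beyond the scatter). That step sits on the aromatic nitrogen of the core and not at the position now being changed.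

Compound 4 `Nc1ccccc1NC(=O)/C=C/c1ccc(Cn2cnc3c(NC4CCCCC4)nc(Cl)nc32)cc1` differs from compound 1 in that (cyclohexylamino in place of 4-methylpiperidin-1-yl on an aromatic carbon). Within the data shown here, no measured step covers a change of this kind at this position. The step from compound 2 to compound 3 is the sole indication of how far a single replacement can move the read-out in this series, and it was large. Among the measured compounds shown here, compound 3 shows the highest number of the three, but compound 3 and compound 1 differ in more than one place, so no step between them can be drawn. On this footing an upward move from compound 1 is expected, of the order of a number 17.2 percentage points higher from compound 1 to compound 4 (beyond the scatter), with wide uncertainty. Compound 4 is therefore expected to give about 28% in this assay, within a range of 8% to 50%.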

Compound 4, a percentage reported as inhibition, at one concentration (the size of the read-out at that concentration, not a potency): 24.9%
For compound 4 the middle estimate is 3.1 percentage points above the measured one, and the stated range covers the measured number.
By their numbers in this assay, from the lowest: compound 1; then compounds 2 and 4 (each within the scatter of the next); then compound 3.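

Within the data shown here, the position on the aromatic carbon next to the ring nitrogen responds to substitution: in this assay, replacing 4-methylpiperidin-1-yl with cyclohexylamino gives a number 14.1 percentage points higher from compound 1 to compound 4 (beyond the scatter), the first measured step at this site. The two groups have the same atoms, joined differently, so this read-out is sensitive to how those atoms are arranged and not only to their number; the entering group also carries a hydrogen-bond donor that the leaving group lacks. Nothing in hand accounts for the rise or assigns it to either difference between the two groups.

The ring carbon-only character and the amine hydrogen change together in this one step, so their contributions remain inseparable; cyclohexyl(methyl)amino at the same carbon would have no amine hydrogen, and piperidin-1-yl or morpholin-4-yl would show how far the ring itself matters. Also open, going by these compounds, is whether smaller or larger amines, such as cyclopentylamino or cycloheptylamino, carry the read-out further from the level of compound 4 on the core of compound 1.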